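Triazole-linked chalcones: aryl swap on the ring nitrogen

The source may report more compounds than this note shows. Statements on the series, on what has been measured and on what is new or still open speak of the compounds shown alone.

Measured compounds:
compound 1 `COc1ccc(-n2cc(COc3ccc(/C=C/C(=O)c4cc5c(cc4O)OC(C)(C)CC5)cc3)nn2)c([N+](=O)[O-])c1`, 99500 nM
compound 2 `CC(=O)c1ccc(-n2cc(COc3ccc(/C=C/C(=O)c4cc5c(cc4O)OC(C)(C)CC5)cc3)nn2)cc1`, 66300 nM
compound 3 `COc1ccc(-n2cc(COc3ccc(/C=C/C(=O)c4ccc5c(c4O)CCC(C)(C)O5)cc3)nn2)c([N+](=O)[O-])c1`, "not active" (no number reported)

In a functional assay on A549 cells (Homo sapiens) for antiproliferative activity, read by MTT assay (on this read-out lower numbers stand for stronger inhibition and higher numbers for weaker inhibition), compound 1 gives 99500 nM and compound 2 gives 66300 nM; the step of a 1.5-fold lower number from compound 1 to compound 2 (0.18 log units; within the scatter) is the change (4-acetylphenyl in place of 4-methoxy-2-nitrophenyl on an aromatic nitrogen). Compound 3 carries the core atoms of compound 1 joined differently; the difference between the two cores is not broken down here. In this assay compound 3 is reported as "not active" (no number reported), with no number. Compound 4 `CC(=O)c1ccc(-n2cc(COc3ccc(/C=C/C(=O)c4ccc5c(c4O)CCC(C)(C)O5)cc3)nn2)cc1` is not yet measured; it relates to compound 3 by the same change, (4-acetylphenyl in place of 4-methoxy-2-nitrophenyl on an aromatic nitrogen), at the same place. Since the earlier step from compound 1 to compound 2 stayed within the scatter, a step of similar small size is expected here, resting on a 1.5-fold lower number from compound 1 to compound 2 (0.18 log units; within the scatter). Given that compound 3 returned no number, compound 4 is expected near 150000 nM, in the range 60000 nM to 400000 nM, with a real chance of only an inactive call.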

Compound 4, half-maximal inhibitory concentration: 149000 nM
The estimate for compound 4 lay 1.0-fold (0.00 log units) above the measured number; the range from low to high includes it.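

Among the compounds shown here, compound 3 has no number, so no step from compound 3 to compound 4 can be read. The compounds shown leave open whether 4-acetylphenyl in place of 4-methoxy-2-nitrophenyl shifts activity on the core of compound 3 at all. No measured evidence bears on this result.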